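The compounds below may be only part of what the source reports. "The series", "measured", "known", "first", "only" and "open" are said of these compounds alone.

Among the compounds with values here, in a functional assay on HeLa cells (Homo sapiens) for cytotoxicity, read by resazurin assay, with a stated time of 72 h (on this read-out lower numbers stand for stronger inhibition and higher numbers for weaker inhibition), compound 1 (`COc1cc(/C=C/C(=O)OCCCO[N+](=O)[O-])ccc1OCCCO[N+](=O)[O-]`) gives 3620 nM, the lowest of the three numbers measured so far. Compound 2 (`COc1cc(/C=C/C(=O)OCc2c(-c3ccccc3)no[n+]2[O-])ccc1O`) gives 7820 nM, and compound 3 (`COc1cc(/C=C/C(=O)Oc2ccc(OCc3c(-c4ccccc4)no[n+]3[O-])cc2)ccc1O`) gives 12100 nM. The gaps from compound 1 to both of these lie beyond the usual scatter, so compound 1 stands as the strongest inhibitor of the three.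

The next compound, compound 4 (`COc1cc(/C=C/C(=O)OCCCO[N+](=O)[O-])ccc1O`), has not yet been measured. It differs from compound 1 by hydrogen in place of 3-(nitrooxy)propyl on an oxygen on an aromatic ring. The same difference, cut one bond further out, reads 3-(nitrooxy)propoxy to hydroxy.

Within the data shown here, none of the measured compounds differs from another in one place alone, so the size of this step has no direct measure. The nearest guide is indirect. Compound 2 carries the same hydroxy and gives 7820 nM, and compound 3 also carries it and gives 12100 nM, both higher than compound 1. A moderate move toward weaker inhibition in this assay is therefore expected, and the estimated step is a 2.5-fold higher number from compound 1 to compound 4 (0.40 log units; beyond the scatter). For compound 4 the expected value is 9000 nM, with an estimated range from 3500 nM to 25000 nM.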

Compound 4, half-maximal inhibitory concentration: 6700 nM
Estimate against measurement, compound 4: 1.3-fold (0.13 log units) above, within the range that was stated.
By their numbers in this assay, from the lowest: compounds 1, 4, 2 and 3 (each within the scatter of the next, the first and the last beyond it).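

In this assay, hydrogen in place of 3-(nitrooxy)propyl on an oxygen on an aromatic ring gives a 1.9-fold higher number from compound 1 to compound 4 (0.27 log units; within the scatter), the first direct measure of this change, and the step lies within the usual scatter. For this one pair, then, the read-out does not separate the compound bearing 3-(nitrooxy)propoxy at this position from the one bearing hydroxy, so this chain is not shown to be needed for the activity of compound 1 in this assay; compound 1 and compound 4 still share their other 3-(nitrooxy)propyl group, and this single pair says nothing about that group. No measurement at hand explains why the step is this small.

As far as these compounds go, whether a methyl group, an acetyl group or a longer chain ending in nitrooxy on this same oxygen would move the number beyond the scatter remains open. From the compounds shown here alone, it is also open how the shared 3-(nitrooxy)propyl group contributes, a question that a plain propyl chain in its place, with the hydroxy kept, would address directly.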